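The compounds below may be only part of what the source reports. "The series", "measured", "known", "first", "only" and "open" are said of these compounds alone.

Measured so far in an ADME assay on microsomes from liver (Mus musculus) for metabolic stability, read by LC-MS, with a stated time of 40 min, tested at 0.5 uM; a lower number here means slower removal, a higher number faster removal of the compound:
- compound 1 `CC(C)S(=O)(=O)c1cccc(NC(=O)c2cccnc2N2CCC3(CC2)CC3)c1`: > 399 mL.min-1.g-1, a limit
- compound 2 `CC(C)(C)NS(=O)(=O)c1cccc(NC(=O)c2cccnc2N2CCC3(CC2)CC3)c1`: > 399 mL.min-1.g-1, a limit

Neither entry is an exact number. Compound 2 stands at the limit of > 399 mL.min-1.g-1 in this assay, at which 2 of the 2 values shown sit. Among the measured compounds shown here, the only measured step is a step that the two limits leave unreadable from compound 1 to compound 2, where (tert-butyl)amino takes the place of isopropyl on a sulfonyl sulfur. That step has no readable size, so it offers no size to carry forward.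

Compound 3 `O=C(Nc1cccc(S(=O)(=O)NC2CC2)c1)c1cccnc1N1CCC2(CC1)CC2` has cyclopropyl in place of tert-butyl on a sulfonamide nitrogen. With no readable size to draw on, no step beyond the scatter is expected in this assay, and removal is expected to stay fast. The expected change is an at least 1.1-fold lower number from compound 2 to compound 3 (0.05 log units; that floor lies within the scatter). Compound 3 is estimated at 350 mL.min-1.g-1, with an expected range of 170 mL.min-1.g-1 to 700 mL.min-1.g-1.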

Compound 3, intrinsic clearance in microsomes: > 399 mL.min-1.g-1
Compound 3 gave a limit, no number; the forecaster's own chance of this, stated with the estimate: 55%; at least 1.1-fold (0.05 log units) between middle value and limit.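

In this assay compound 3 gives > 399 mL.min-1.g-1 as a limit, not a number. Among the compounds shown here, no step among compound 1, compound 2 and compound 3 can be read, as all three sit at one limit: the limit of > 399 mL.min-1.g-1 in this assay, at which 3 of the 3 values shown sit.
The compounds shown leave open how fast each is actually removed and whether any of these changes on the sulfonyl sulfur slows removal.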